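The source may report more compounds than this note shows. Statements on the series, on what has been measured and on what is new or still open speak of the compounds shown alone.

Compound 1 `O=C(O)C1=Cc2ccccc2OC1(OCc1cc(-c2ccc(F)cc2)no1)C(F)(F)F` has the highest number of the two measured here: in a functional assay on DU-145 cells (Homo sapiens) for inhibition, read by MTT assay, with a stated time of 24 h (on this read-out higher numbers stand for weaker inhibition and lower numbers for stronger inhibition), compound 1 gives 168000 nM. Compound 2 `CCOC(=O)C1=Cc2ccccc2OC1(OCc1cn(-c2ccc(F)c(Cl)c2)nn1)C(F)(F)F` in this assay gives 21500 nM, a gap beyond the scatter, but compound 2 differs from compound 1 in more than one place and so says nothing about any single change. Compound 3 `O=C(O)C1=Cc2ccccc2OC1(OCc1cc(-c2ccc3ccccc3c2)no1)C(F)(F)F` is the only unmeasured entry; it differs from compound 1 as follows: naphthalen-2-yl in place of 4-fluorophenyl on an aromatic carbon. Within the data shown here, no measured step matches this change, so the expectation rests on compound 1 alone. The step is expected to be small, toward stronger inhibition: a 1.7-fold lower number from compound 1 to compound 3 (0.23 log units; within the scatter). Compound 3 is accordingly estimated at 100000 nM, with a range from 30000 nM to 350000 nM.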

Compound 3, half-maximal inhibitory concentration: 141000 nM
Beside the measured number, compound 3's estimate is 1.4-fold (0.15 log units) below it, and the stated range covers the measured number.
By their numbers in this assay, from the lowest: compound 2; then compounds 3 and 1 (each within the scatter of the next).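

Naphthalen-2-yl in place of 4-fluorophenyl, on the aromatic carbon next to the ring nitrogen, gives a 1.2-fold lower number from compound 1 to compound 3 (0.08 log units; within the scatter) in this assay. This position therefore accepts a second six-membered aromatic ring with no difference beyond the scatter, and compound 3 stays in the same weak range as compound 1. No evidence bearing on the reason for this result is available.

Open, from the compounds shown here alone, is whether an amine or a short alkyl chain on this carbon, in place of an aromatic ring, would give a step beyond the scatter.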